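The source may report more compounds than this note shows. Statements on the series, on what has been measured and on what is new or still open speak of the compounds shown alone.

Measured so far:
compound 1, `CCCCCCS(=O)(=O)N[C@H]1C2CC[C@H](C2)[C@@H]1C/C=C\CCCC(=O)O`: 13300 nM in a functional assay (plasma) for inhibition, with Oryctolagus cuniculus as the target; a higher number here means a weaker inhibitor, a lower number a stronger inhibitor
compound 2, `CCCCCc1ccc(S(=O)(=O)N[C@H]2C3CC[C@H](C3)[C@@H]2C/C=C\CCCC(=O)O)cc1`: 800000 nM in this assay
compound 3, `Cc1ccccc1S(=O)(=O)N[C@H]1C2CC[C@H](C2)[C@@H]1C/C=C\CCCC(=O)O`: 6200 nM in this assay

Compound 3 gives the lowest number of the three. For the measured compounds named here, the nearest value is that of compound 1, and the one step measured on the sulfonyl substituent is a 2.1-fold lower number from compound 1 to compound 3 (0.33 log units; beyond the scatter), a modest gain. Compound 2 stands far off with a much higher number than compound 3.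

Compound 4, `COc1ccc(S(=O)(=O)N[C@H]2C3CC[C@H](C3)[C@@H]2C/C=C\CCCC(=O)O)cc1`, is not yet measured. It differs from compound 3 in one place: 4-methoxyphenyl in place of 2-methylphenyl on a sulfonyl sulfur. Going by the values given here, no measured step tests a methoxy group on this ring. The other measured compound carrying a six-membered aromatic ring on the sulfonyl sulfur, compound 2, gives 800000 nM, far weaker than compound 3, which warns that alterations on that ring can cost a great deal. Compound 4 is therefore expected to come out weaker than compound 3, a 4.8-fold higher number from compound 3 to compound 4 (0.68 log units; beyond the scatter), with wide uncertainty. The estimate for compound 4 in this assay is 30000 nM, range 8000 nM to 150000 nM.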

Compound 4, half-maximal inhibitory concentration: 1700 nM
Beside the measured number, compound 4's estimate is 18-fold (1.25 log units) above it; measured number outside the range, below it.
By their numbers in this assay, from the lowest: compound 4; then compound 3; then compound 1; then compound 2.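

In this assay, an aromatic ring on the sulfonyl sulfur carrying a group other than the methyl of compound 3 can give a lower number, as 4-methoxyphenyl does in place of 2-methylphenyl (a 3.6-fold lower number from compound 3 to compound 4 (0.56 log units; beyond the scatter)) and in place of hexyl (a 7.8-fold lower number from compound 1 to compound 4 (0.89 log units; beyond the scatter)). The very high number of compound 2 therefore does not follow from a substituted ring alone: the group on the aromatic carbon weighs heavily here, with methoxy in place of pentyl giving the largest step in the series (a 470-fold lower number from compound 2 to compound 4 (2.67 log units; beyond the scatter)). No measurement at hand accounts for these steps.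

The step to 4-methoxyphenyl changes both the group and its place on the ring, so 4-methylphenyl and 2-methoxyphenyl would be needed to separate the two. Also open, on these data alone, is where an unsubstituted phenyl or a shorter chain such as ethyl falls between methoxy and pentyl.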